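Working notes: amine ring variation, compound 1 to compound 3

The source may report more compounds than this note shows. Statements on the series, on what has been measured and on what is new or still open speak of the compounds shown alone.

Measured so far:
Compound 1 `C(=C/c1ccccc1OCCCCN1CCCC1)\c1ccccc1` gives 42.9% in a functional assay on the whole organism with Mus musculus as the target, in the maximal electroshock model, at a dose of 50 mg/kg by the oral route; a lower number here means less inhibition, a higher number more inhibition at the dose given (going by the name of the read-out).
Compound 2 `CN1CCN(CCCCOc2ccccc2/C=C/c2ccccc2F)CC1` gives 0% in this assay.

Compound 1 stands highest of the two numbers. Its nearest neighbour is compound 2, whose number lies a good way lower, beyond the scatter. Among the compounds with values here, no pair of measured compounds differs in one place only, so the two values show no more than this: compound 1 inhibits at the dose given and compound 2 does not, with no single change to which the gap can be tied.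

Compound 3 `CC1CCCN(CCCCOc2ccccc2/C=C/c2ccccc2)C1` is not yet measured. It differs from compound 1 in one place: 3-methylpiperidin-1-yl in place of pyrrolidin-1-yl on a saturated chain carbon, four bonds along the chain from an oxygen on an aromatic ring. Within the data shown here, nothing measured bears on this change; no compound with a different amine ring and otherwise the same build as compound 1 has a value. Among the measured compounds shown here, the expected step is a number 2.1 percentage points higher from compound 1 to compound 3 (within the scatter), small and in no firm direction, since the only guide is compound 1 itself with 42.9%. Compound 3 is estimated at 45%, with a range from 15% to 75%.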

Compound 3, a percentage reported as inhibition, in the whole organism at one dose (the size of the read-out at that dose, not a potency): 12.5%
Compound 3: the middle estimate sits 32.5 percentage points above what was measured; measured number below the stated range.
By their numbers in this assay, from the lowest: compound 2; then compound 3; then compound 1.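

Within the data shown here, the amine ring at this position now has a measured effect in this assay: 3-methylpiperidin-1-yl in place of pyrrolidin-1-yl, on a saturated chain carbon, four bonds along the chain from an oxygen on an aromatic ring, gives a number 30.4 percentage points lower from compound 1 to compound 3 (beyond the scatter) and is the first step tied to one change. The step replaces a five-membered non-aromatic ring of 5 heavy atoms with a six-membered one of 7, while the counts of hydrogen-bond donors and acceptors and the net charge stay the same, so the larger ring and the added methyl arrive together and this step cannot separate them. No measurement shown here offers an explanation for the drop.

Going by these compounds, it remains open whether plain piperidin-1-yl, without the methyl, would stay with compound 1 or fall with compound 3, which would separate the ring size from the methyl. On these data alone, it is also open how 4-methylpiperazin-1-yl or morpholin-4-yl would read on the core of compound 1, since compound 2 differs from compound 1 in more than one place and cannot yet be linked to this step.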